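The source may report more compounds than this note shows. Statements on the series, on what has been measured and on what is new or still open speak of the compounds shown alone.

Compound 1 `Cc1c(-c2ccc(Cc3ccc(C(C)(C)C)cc3)cc2)[nH]c2cccc(F)c2c1=O`, compound 2 `Cc1c(-c2ccc(Cc3ccc(C(C)(O)C(F)(F)F)cc3)cc2)[nH]c2cccc(F)c2c1=O` and compound 3 `Cc1c(-c2ccc(Cc3ccc(Cl)cc3)cc2)[nH]c2cccc(F)c2c1=O` share one core and differ in a single group on an aromatic carbon. In an ADME assay on Huh7.5.1 cells (Homo sapiens) for cytotoxicity, read by WST assay, with a stated time of 48 h (on this read-out lower numbers stand for higher toxicity in this test and higher numbers for lower toxicity in this test), compound 3 gives > 10000 nM, which is a limit of the assay and not a number. Compound 1 gives > 5000 nM, again a limit. Compound 2 gives > 2500 nM, also a limit. None of the three therefore has a measured number, and compound 3 can be placed only by its limit.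

Compound 4 `COc1ccc(Cc2ccc(-c3[nH]c4cccc(F)c4c(=O)c3C)cc2)cc1` carries methoxy in place of chloro on an aromatic carbon, para to a large group: methoxy in place of chloro on an aromatic carbon. Two measured exchanges at that carbon bear on this change, and neither has a readable size. Within the data shown here, the first is a step that the two limits leave unreadable from compound 1 to compound 3, and the second is a step that the two limits leave unreadable from compound 2 to compound 3. These steps give no sign that a group exchange at this carbon moves the result, so no step beyond the usual scatter is expected in this assay, and no direction can be expected. The estimated step is a number no higher from compound 3 to compound 4 (the limit leaves the size open). For compound 4 the estimated value is 10000 nM, with an expected range from 4000 nM to 25000 nM, and the result may well be another limit.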

Compound 4, half-maximal cytotoxic concentration: > 10000 nM
Compound 4 was reported as a limit; the forecaster's own chance of this, stated with the estimate: 85%; the middle value lies on the limit itself.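

In this assay compound 4 gives > 10000 nM, which is a limit of the assay and not a number. Compound 1, compound 2 and compound 3 also stand only as limits, so no new step can be read between compound 4 and any of them. The compounds shown leave open where the true values lie and whether exchanging the group on this aromatic carbon changes the result at all.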